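The compounds below may be only part of what the source reports. "The series", "measured", "known", "first", "only" and "open" are said of these compounds alone.

Measured compounds:

Compound 1 `O=C(O)c1cnc(-c2ccccc2[N+](=O)[O-])[nH]c1=O`: in a functional assay on the whole organism (strain Sprague-Dawley) for inhibition, with Rattus norvegicus as the target, with a stated time of 10 min (a higher number here means that more compound is needed for the effect, a lower number that less compound is needed), compound 1 gives > 50 mg/kg, which is a limit of the assay and not a number.
Compound 2 `COc1ccccc1-c1ncc(C(=O)O)c(=O)[nH]1`: in this assay compound 2 gives 10 mg/kg.
Compound 3 `CCOC(=O)c1cnc(-c2ccccc2OC)[nH]c1=O`: in this assay compound 3 gives 10 mg/kg.

Compound 3 stands level with compound 2 at the digits shown; the step of no change at the digits printed from compound 2 to compound 3 (within the scatter) lies within the scatter. Among the measured compounds shown here, the one clear step in the set is an at least 5.0-fold lower number from compound 1 to compound 2 (0.69 log units; beyond the scatter), and it rests on (the limit of > 50 mg/kg in this assay, at which 1 of the 3 values shown sits).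

Compound 4 `CCOC(=O)c1cnc(-c2ccccc2SCC)[nH]c1=O` differs from compound 3 by ethylsulfanyl in place of methoxy on an aromatic carbon, on an aromatic carbon of a six-membered aromatic ring of carbon only, ortho to a large group. For the measured compounds named here, no measured step exchanges one such group for another at that place. The step of an at least 5.0-fold lower number from compound 1 to compound 2 (0.69 log units; beyond the scatter) shows that a change at this carbon can matter, while no change at the digits printed from compound 2 to compound 3 (within the scatter) shows the ester end tolerates alteration. Nothing measured here speaks for a step beyond the scatter in this assay for compound 4, so the expectation is an estimated 1.2-fold higher number from compound 3 to compound 4 (0.08 log units; within the scatter), and compound 4 is expected at about 12 mg/kg (range 4 mg/kg to 40 mg/kg).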

Compound 4, dose for 50% inhibition: > 5 mg/kg
Compound 4 was reported as a limit; the forecaster's own chance of this, stated with the estimate: 15%; the middle value lies beyond the limit too.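

In this assay compound 4 gives > 5 mg/kg, which is a limit of the assay and not a number. No step from compound 3 to compound 4 can be read: the limit of > 5 mg/kg in this assay, at which 1 of the 4 values shown sits.

The compounds shown leave open whether ethylsulfanyl in place of methoxy changes the result in this assay, and in which direction.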